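Swapping Fluoro for Bromo on a Benzyl Arm

This account rests on a few compounds, and the source may have more. Where it says the series, first, only, none or still open, it means among the compounds named here.

Compound 2, `O=C(CCC1=CCCN(CCCc2ccc(-c3ccccc3)cc2)C1=O)NO`: 1040 nM
Compound 3, `O=C(CCC1=CCCN(CCCCc2cccc3ccccc23)C1=O)NO`: 1470 nM
Compound 1, `O=C(CCC1=CCCN(Cc2ccc(F)cc2)C1=O)NO`: "not determined" (no result reported)

The values above come from a functional assay on MDA-MB-231 cells (Homo sapiens) for inhibition, read by sulforhodamine B assay; a higher number here means a weaker inhibitor of growth, a lower number a stronger inhibitor of growth. Compound 2 and compound 3 carry long arms on the shared core and land close to each other in this assay, within the usual scatter, so nothing separates them. Compound 1 carries a much shorter arm, a 4-fluorophenyl on a single carbon, and no number stands for it in this assay; it cannot be placed against the other two.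

The compound to be measured is compound 4, `O=C(CCC1=CCCN(Cc2ccc(Br)cc2)C1=O)NO`. Its change from compound 1 is bromo in place of fluoro on an aromatic carbon. Both halogens sit at the same place, and the rest of the molecule is untouched. Within the data shown here, with no measured pair of this kind to lean on, the expected step in this assay is none beyond the scatter, in no particular direction. Taking compound 2 and compound 3 as the only guide to the series, compound 4 is estimated to give 1800 nM, with a range from 500 nM to 6000 nM.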

Compound 4, concentration for 50% growth inhibition: 1630 nM
For compound 4 the middle estimate is 1.1-fold (0.04 log units) above the measured one, and the stated range covers the measured number.
By their numbers in this assay, from the lowest: compounds 2, 3 and 4 (each within the scatter of the next).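

With compound 1 at "not determined" (no result reported) in this assay, no step can be read for the swap of fluoro for bromo that leads to compound 4. As far as these compounds go, whether 4-fluorophenyl and 4-bromophenyl differ in growth inhibition stays open, and no evidence here bears on this result.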